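A few compounds are considered here, and "the series" means these few. Any claim that something is new, unique, unknown or untested is made for them only; others in the source may bear on it.

Compound 1 `Cc1ccc(C(=O)c2ccc(C(=O)c3ccc(C(=O)O)cc3)cc2)cc1` stands at the lower of the two numbers in hand: in an assay on CHO cells for inhibition of 3-oxo-5-alpha-steroid 4-dehydrogenase 2 (Homo sapiens) (on this read-out higher numbers stand for weaker inhibition and lower numbers for stronger inhibition), compound 1 gives 10 nM. Compound 2 `O=C(O)c1ccc(C(=O)c2ccc(Oc3ccc([N+](=O)[O-])cc3)cc2)cc1` gives 20 nM, which lies within the scatter of compound 1, so the two cannot be ranked. Compound 3 `O=C(O)c1ccc(C(=O)c2ccc(C(=O)Cc3ccccc3)cc2)cc1` has not yet been measured. It differs from compound 1 by benzyl in place of 4-methylphenyl on a carbonyl carbon. Going by the values given here, no measured step of this kind exists among the compounds in hand, so a move beyond the scatter in either direction cannot be excluded, though a modest weakening is expected. The expected step is a 2.0-fold higher number from compound 1 to compound 3 (0.30 log units; within the scatter). Compound 3 is estimated at 20 nM, in the range 5 nM to 80 nM.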

Compound 3, inhibition constant: 40 nM
For compound 3 the middle estimate is 2.0-fold (0.30 log units) below the measured one; low and high end bracket the measured number.
By their numbers in this assay, from the lowest: compounds 1, 2 and 3 (each within the scatter of the next, the first and the last beyond it).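

Going by these compounds alone, on a carbonyl carbon, benzyl in place of 4-methylphenyl gives a 4.0-fold higher number from compound 1 to compound 3 (0.60 log units; beyond the scatter) in this assay and so provides the first measured step at this place. The two groups match in everything counted, each with 7 carbon atoms and one six-membered aromatic ring, yet the number still moves beyond the scatter. Nothing in hand accounts for this step. The compounds shown leave open how a longer chain such as 2-phenylethyl, or an amine, would read at this carbonyl carbon. They also leave open whether a plain phenyl would stay within the scatter of compound 1.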